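Shifting the Ethoxy Group: From Compound 3 to Compound 4

The compounds below may be only part of what the source reports. "The series", "measured", "known", "first", "only" and "open" are said of these compounds alone.

Compound 1, `O=C1C(Nc2cccc(Cl)c2)=CC(=O)c2c1nc1n2[C@H]2OC[C@@H](O)[C@H]2OC1`: 7970 nM
Compound 2, `COc1ccc(NC2=CC(=O)c3c(nc4n3[C@H]3OC[C@@H](O)[C@H]3OC4)C2=O)cc1`: > 8000 nM (a limit)
Compound 3, `CCOc1ccc(NC2=CC(=O)c3c(nc4n3[C@H]3OC[C@@H](O)[C@H]3OC4)C2=O)cc1`: 14400 nM

The three measured compounds share one core and differ only in the aryl group on the amine nitrogen. In a functional assay on HeLa cells (Homo sapiens) for inhibition, read by sulforhodamine B assay (a higher number here means a weaker inhibitor, a lower number a stronger inhibitor), compound 1 gives 7970 nM. Compound 2 reaches only an assay limit of > 8000 nM in this assay. Compound 3 gives 14400 nM in this assay, the highest of the two numbers shown; its nearest neighbour is compound 1, and the step of a 1.8-fold higher number from compound 1 to compound 3 (0.26 log units; within the scatter) stays within the scatter. The step of a number no lower from compound 1 to compound 2 (the limit leaves the size open) ends at a limit, as does a step that the limit leaves unreadable from compound 2 to compound 3, so neither can be sized (the limit of > 8000 nM in this assay, at which 1 of the 3 values shown sits).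

Compound 4, `CCOc1ccccc1NC1=CC(=O)c2c(nc3n2[C@H]2OC[C@@H](O)[C@H]2OC3)C1=O`, is not yet measured. It differs from compound 3 by 2-ethoxyphenyl in place of 4-ethoxyphenyl on an amine nitrogen. Among the compounds with values here, none of the measured steps moves an ethoxy group around the ring; the only comparison that bears on it is the exchange of aryl groups in a 1.8-fold higher number from compound 1 to compound 3 (0.26 log units; within the scatter), which lies within the scatter. With all three neighbours weak and close together, the step of a 1.2-fold lower number from compound 3 to compound 4 (0.08 log units; within the scatter) that is expected has no clear direction beyond the scatter. Compound 4 is therefore estimated at 12000 nM in this assay, between 5000 nM and 40000 nM, with a real chance that only a limit is reported.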

Compound 4, half-maximal inhibitory concentration: 8300 nM
Compound 4: middle estimate off by 1.4-fold (0.16 log units), on the high side; measured number inside the range.
By their numbers in this assay, from the lowest: compounds 1, 4 and 3 (each within the scatter of the next).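

Within the data shown here, exchanging 4-ethoxyphenyl for 2-ethoxyphenyl on the amine nitrogen is the first change here that keeps the same atoms and alters only how they are joined, and in this assay it gives a 1.7-fold lower number from compound 3 to compound 4 (0.24 log units; within the scatter). Exchanging 3-chlorophenyl for 2-ethoxyphenyl at the same nitrogen gives a 1.0-fold higher number from compound 1 to compound 4 (0.02 log units; within the scatter), so neither the placing of the ethoxy group on the ring nor this exchange of aryl groups separates these compounds beyond the scatter. The value of compound 2 is a limit, so its step to compound 4, like its earlier steps, cannot be read: the limit of > 8000 nM in this assay, at which 1 of the 4 values shown sits.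

The compounds shown leave open whether 3-ethoxyphenyl on the same nitrogen would also fall within the scatter of these values, which would complete the series of ethoxy placements. They also leave open whether any aryl group of a different kind, such as one carrying a carboxylic acid, a dimethylamino group or a longer alkoxy chain, would give a step beyond the scatter in this assay.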